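Swapping the Aryl Amide Cap in an Arylsulfonamide Series

This account rests on a few compounds, and the source may have more. Where it says the series, first, only, none or still open, it means among the compounds named here.

Three compounds from one study share a core in which an aromatic amide is linked through a sulfonamide to a second aromatic ring. Compound 1 has the structure `O=C(NS(=O)(=O)c1ccc(NC(=O)c2ccc(Cl)cc2Cl)cc1)c1ccccc1`, and compound 2 the structure `COc1ccc(NS(=O)(=O)c2ccc(NC(=O)c3ccc(Cl)cc3Cl)cc2)cc1`. In a functional assay on HEK293 cells for agonist activity at probable G-protein coupled receptor 27 (Homo sapiens), read by a luciferase reporter and beta-arrestin recruitment, with a stated time of 10 min (on this read-out higher numbers stand for larger maximal responses and lower numbers for smaller maximal responses), compound 1 gives "not determined" (no result reported), and compound 2 likewise gives "not determined" (no result reported), so neither provides a number to compare against. Compound 3, with the structure `Cc1cc(Cl)ccc1C(=O)Nc1ccc(S(=O)(=O)Nc2ccccc2)cc1`, is the only one with a result: in this assay compound 3 gives 123%, a maximal response somewhat larger than that of the reference. It therefore stands alone as the reference point within this set.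

Compound 4, with the structure `N#Cc1ccc(C(=O)Nc2ccc(S(=O)(=O)Nc3ccccc3)cc2)c(F)c1`, is not yet measured. It differs from compound 3 in one place: 4-cyano-2-fluorophenyl in place of 4-chloro-2-methylphenyl on a carbonyl carbon

Among the compounds with values here, no pair of measured compounds here differs in a single place, so there is no step from which to read how such a change usually plays out. The expectation for compound 4 is accordingly wide. The estimated step of a number 33 percentage points lower from compound 3 to compound 4 (beyond the scatter) is expected to be a moderate fall beyond the scatter, with compound 4 expected to give 90% in this assay, within a range of 40% to 130%.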

Compound 4, largest response reached (Emax), in percent of the reference or control that the assay uses: 29%
For compound 4 the middle estimate is 61 percentage points above the measured one; the measured number lies below the stated range.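

In this assay, within the data shown here, replacing 4-chloro-2-methylphenyl with 4-cyano-2-fluorophenyl on the carbonyl carbon gives a number 94 percentage points lower from compound 3 to compound 4 (beyond the scatter), the first step in this set that can be read. It shows that the maximal response depends strongly on the aromatic group at this position, since the rest of compound 3 and compound 4 is the same and does not by itself preserve the response. The data shown contain no measurement that explains the drop.

This single step changes two features of the ring together, with chlorine and methyl leaving while nitrile and fluorine enter, so the compounds shown cannot separate the contribution of either incoming group or tell whether one alone would produce a similar fall. Among these compounds, also open is how the maximal response would change with an amine or a carboxylic acid on this aromatic ring, and whether this same swap would have a similar effect on a different sulfonamide partner, such as the one in compound 1 or compound 2.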